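Aminopyrazole replaces isopropyl on the shared core

The source may report more compounds than this note shows. Statements on the series, on what has been measured and on what is new or still open speak of the compounds shown alone.

Going by the values given here, compound 2 `CC(C)Nc1ncnn2cccc12` gives 125000 nM in an assay on isolated protein for binding affinity to mitogen-activated protein kinase kinase kinase kinase 4 (Homo sapiens), read by surface plasmon resonance (a lower number here means tighter binding, a higher number weaker binding), the lowest of the two numbers so far, with compound 1 `CNc1ncnn2cccc12` at 155000 nM nearest; the step of a 1.2-fold lower number from compound 1 to compound 2 (0.09 log units; within the scatter) is within the scatter. Compound 3 `c1cc2c(Nc3cn[nH]c3)ncnn2c1` carries 1H-pyrazol-4-yl in place of isopropyl on a nitrogen on an aromatic ring. Among the compounds with values here, only that step bears on the move to compound 3, and it was small, while the new change is of another kind, so no measured step sets its size; a modest fall in the number is expected, a 3.1-fold lower number from compound 2 to compound 3 (0.49 log units; beyond the scatter). For compound 3 the estimate is 40000 nM, within 8000 nM to 200000 nM.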

Compound 3, dissociation constant: 17000 nM
For compound 3 the middle estimate is 2.4-fold (0.37 log units) above the measured one, within the range that was stated.
By their numbers in this assay, from the lowest: compound 3; then compounds 2 and 1 (each within the scatter of the next).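

On a nitrogen on an aromatic ring the substituent can move the number: 1H-pyrazol-4-yl in place of isopropyl gives a 7.4-fold lower number from compound 2 to compound 3 (0.87 log units; beyond the scatter) and in place of methyl gives a 9.1-fold lower number from compound 1 to compound 3 (0.96 log units; beyond the scatter) while the step between the two alkyl groups stayed within the scatter. The entering group adds a five-membered aromatic ring, a hydrogen-bond donor and a hydrogen-bond acceptor together, so these features cannot be separated here. No available evidence accounts for the step.

From the compounds shown here alone, whether the ring itself or its nitrogens carry the step remains open. A phenyl group at the same nitrogen would separate the two.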